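The compounds below may be only part of what the source reports. "The series", "measured", "known", "first", "only" and "open" are said of these compounds alone.

Measured compounds:
Compound 1, `O=C(OCC1CCCN(CCCc2ccccc2)C1)c1ccc(-c2ccccc2)cc1`: 18600 nM
Compound 2, `CC1CC(=O)N(c2ccccc2C(=O)OCC2CCCN(CCCCCc3ccccc3)C2)C1=O`: 4170 nM
Compound 3, `O=C(Nc1ccccc1)c1ccccc1-c1ccccc1`: 10700 nM

In an in vitro functional assay on HEK ts201 cells for antagonist activity at Neuronal acetylcholine receptor; alpha3/beta4 (Homo sapiens), read by fluorescence and calcium flux (on this read-out higher numbers stand for weaker inhibition and lower numbers for stronger inhibition), compound 2 gives 4170 nM, the lowest number of the three. The nearest of the others is compound 3, whose value of 10700 nM stands beyond the scatter of repeated measurements, and compound 1, with 18600 nM, stands further off still. Compound 2 is therefore the strongest inhibitor among the measured compounds on this read-out.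

The unmeasured compound 4, `CC1CC(=O)N(c2ccccc2C(=O)OCC2CCCN(CCCCOc3ccc(Cl)c(Cl)c3)C2)C1=O`, differs from compound 2 in a single place: 3,4-dichlorophenoxy in place of benzyl on a saturated chain carbon, four bonds along the chain from an amine nitrogen in a ring. Among the measured compounds shown here, no pair of measured compounds shows this change, or any other change made one at a time, so the size of the step has no precedent in these data. The author expects compound 4 to stay close to compound 2 in this assay, with a step of a 1.4-fold lower number from compound 2 to compound 4 (0.14 log units; within the scatter) that may well lie within the scatter, though a modest move toward stronger inhibition is considered possible. Compound 4 is estimated at 3000 nM, with a range from 800 nM to 12000 nM.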

Compound 4, half-maximal inhibitory concentration: 74100 nM
For compound 4 the middle estimate is 25-fold (1.39 log units) below the measured one, and the stated range ends below it.
By their numbers in this assay, from the lowest: compound 2; then compounds 3 and 1 (each within the scatter of the next); then compound 4.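

In this assay, putting 3,4-dichlorophenoxy in place of benzyl on a saturated chain carbon, four bonds along the chain from an amine nitrogen in a ring, gives an 18-fold higher number from compound 2 to compound 4 (1.25 log units; beyond the scatter), a large step toward weaker inhibition. Among the compounds shown here, this is the first change in one place that can be read in these compounds, and it shows that this position on the chain does not tolerate every aromatic group equally, which the earlier compounds, with no such pair among them, could not show. Nothing in the data shown accounts for the size of this step.

The change brings in the chain oxygen and the two chlorines together, so the compounds shown leave open whether a plain phenoxy group or a 3,4-dichlorobenzyl group would give a number closer to that of compound 2 or to that of compound 4. Also open, as far as these compounds go, is how a single chlorine on the ring, or an amine or a carboxylic acid at the same place on the chain, would read on this measure.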